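Cyclobutyl-to-methylcyclopropyl step with an added chain double bond

The compounds below may be only part of what the source reports. "The series", "measured", "known", "first", "only" and "open" are said of these compounds alone.

Working notes on the series. Compound 2 `COC(=O)CC/C=C\CC[C@H]1C(=O)C[C@@H](O)[C@@H]1/C=C/CC(C)(O)CCC1CCC1` gives 0.316 mg/kg in a functional assay on the whole organism with Rattus norvegicus as the target; a higher number here means that more compound is needed for the effect, a lower number that less compound is needed; it stands second highest of the three numbers, nearest compound 1 `COC(=O)CC/C=C\CC[C@H]1C(=O)C[C@@H](O)[C@@H]1/C=C/CC(C)(O)CCC1CC1` at 0.273 mg/kg and furthest from compound 3 `COC(=O)CC/C=C\CC[C@H]1C(=O)C[C@@H](O)[C@@H]1/C=C/C[C@@](C)(O)/C=C/C1CC1` at 0.402 mg/kg, both gaps within the scatter. Compound 4 `COC(=O)CC/C=C\CC[C@H]1C(=O)C[C@@H](O)[C@@H]1/C=C/C[C@@](C)(O)/C=C/C1(C)CC1` differs from compound 2 thus: 1-hydroxy-1-methyl-3-(1-methylcyclopropyl)prop-2-en-1-yl in place of 3-cyclobutyl-1-hydroxy-1-methylpropyl on a saturated chain carbon bound to a double-bonded chain carbon. The measured steps that bear on this are a 1.3-fold higher number from compound 2 to compound 3 (0.10 log units; within the scatter), a 1.5-fold higher number from compound 1 to compound 3 (0.17 log units; within the scatter) and a 1.2-fold higher number from compound 1 to compound 2 (0.06 log units; within the scatter), none beyond the scatter. Among the compounds with values here, compound 4 adds a methyl on the ring of compound 3, for which no step is available. Compound 4 is therefore expected at 0.4 mg/kg in this assay, range 0.2 mg/kg to 0.8 mg/kg, an expected step of a 1.3-fold higher number from compound 2 to compound 4 (0.10 log units; within the scatter) with no direction beyond the scatter.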

Compound 4, dose for half-maximal effect: 1.34 mg/kg
Compound 4: middle estimate off by 3.4-fold (0.53 log units), on the low side, outside the stated range (above it).
By their numbers in this assay, from the lowest: compounds 1, 2 and 3 (each within the scatter of the next); then compound 4.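

In this assay, within the data shown here, methyl in place of hydrogen on a saturated ring carbon gives a 3.3-fold higher number from compound 3 to compound 4 (0.52 log units; beyond the scatter) and is the first single change to go beyond the scatter. The larger gaps, a 4.2-fold higher number from compound 2 to compound 4 (0.63 log units; beyond the scatter) and a 4.9-fold higher number from compound 1 to compound 4 (0.69 log units; beyond the scatter), set compound 4 apart, whereas the cyclobutyl, cyclopropyl and added chain double bond changes stayed within the scatter. No available data give a cause for this step. Open, from the compounds shown here alone, is whether ethyl on that ring carbon moves the number further, and whether methyl there has the same size of step without the chain double bond.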